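The source may hold more compounds than are shown below. What is called first, only, known or untested is meant among the compounds shown, and "the series" means these compounds.

Compound 3 `Oc1ccc(Nc2cncc(N3CC4CC(C3)N4)c2)cc1` gives the highest number of the three measured compounds in an assay on cell membranes for displacement of a labelled ligand from Neuronal acetylcholine receptor; alpha4/beta2 (Rattus norvegicus) (a lower number here means a stronger inhibitor, a higher number a weaker inhibitor), namely 0.342 nM. Compound 2 `Cc1ccc(Nc2cncc(N3CC4CC(C3)N4)c2)cc1` gives 0.148 nM, and compound 1 `COc1ccc(Nc2cncc(N3CC4CC(C3)N4)c2)cc1` gives 0.0598 nM. The change to compound 4 `Clc1cccc(Nc2cncc(N3CC4CC(C3)N4)c2)c1` is 3-chlorophenyl in place of 4-hydroxyphenyl on a nitrogen on an aromatic ring. Within the data shown here, no measured step makes this exact change; the nearest comparisons are a 2.3-fold higher number from compound 2 to compound 3 (0.36 log units; beyond the scatter) and a 5.7-fold higher number from compound 1 to compound 3 (0.76 log units; beyond the scatter), both modest and both running toward the weaker end at compound 3. Like compound 4, compound 2 carries no hydrogen-bond donor or acceptor, and compound 2 gives 0.148 nM. On that basis compound 4 is expected to show a modest improvement, a step of a 2.3-fold lower number from compound 3 to compound 4 (0.36 log units; beyond the scatter) in this assay. Compound 4 is therefore estimated at 0.15 nM, with a range from 0.04 nM to 0.6 nM.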

Compound 4, inhibition constant: 0.124 nM
For compound 4 the middle estimate is 1.2-fold (0.08 log units) above the measured one; low and high end bracket the measured number.
By their numbers in this assay, from the lowest: compound 1; then compounds 4 and 2 (each within the scatter of the next); then compound 3.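

In this assay, the group on a nitrogen on an aromatic ring can carry a chlorine: replacing 4-hydroxyphenyl with 3-chlorophenyl gives a 2.8-fold lower number from compound 3 to compound 4 (0.44 log units; beyond the scatter). Against 4-methylphenyl, 3-chlorophenyl shows a 1.2-fold lower number from compound 2 to compound 4 (0.08 log units; within the scatter), so these two groups cannot be told apart here. Nothing available explains either step. The compounds shown leave open whether the chlorine or its place on the ring matters, as they include neither 4-chlorophenyl nor 3-methylphenyl. From the compounds shown here alone, how an amine or a carboxylic acid on this phenyl ring would behave also remains open.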